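The source may hold more compounds than are shown below. What is called first, only, known or untested is meant among the compounds shown, and "the series" means these compounds.

Working notes on the series. Compound 1 `CCNC(=O)N1CCN(C(=S)SCc2cn(Cc3ccc(F)cc3)nn2)CC1` carries a 4-fluorobenzyl group on the shared core together with an ethyl urea. In a functional assay on MCF7 cells (Homo sapiens) for cytotoxicity, read by MTT assay, with a stated time of 72 h (a higher number here means a weaker inhibitor, a lower number a stronger inhibitor), compound 1 gives 3660 nM, the only plain number shown for the series so far. Compound 2 `O=C(NC1CCCCC1)N1CCN(C(=S)SCc2cn(Cc3ccc(F)cc3)nn2)CC1` differs from compound 1 only at the urea. In this assay compound 2 reaches only a limit, > 128000 nM. Among the measured compounds shown here, the step of an at least 34-fold higher number from compound 1 to compound 2 (1.54 log units; beyond the scatter) is the sole measured step; it concerns the urea substituent and ends at the limit of > 128000 nM in this assay, at which 1 of the 2 values shown sits. Compound 3 `CCNC(=O)N1CCN(C(=S)SCc2cn(Cc3ccc(C)cc3)nn2)CC1` is not yet measured. It differs from compound 1 by methyl in place of fluoro on an aromatic carbon. For the measured compounds named here, no measured step touches this part of the molecule; the one measured step changes the urea and so does not bear on the benzyl ring. The expectation for compound 3 is therefore no step beyond the scatter, a 1.0-fold higher number from compound 1 to compound 3 (0.00 log units; within the scatter). Compound 3 is estimated at 3700 nM, with a range from 1200 nM to 12000 nM.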

Compound 3, half-maximal inhibitory concentration: > 128000 nM
Compound 3 ended at the assay's limit; the forecaster's own chance of this, stated with the estimate: 10%; middle value at least 34-fold (1.53 log units) from the limit.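

The benzyl ring is not a silent part of the molecule: in this assay, methyl in place of fluoro on an aromatic carbon, para to a large group, gives an at least 34-fold higher number from compound 1 to compound 3 (1.54 log units; beyond the scatter). One heavy atom replaces one heavy atom here, with no change in the count of hydrogen-bond donors or acceptors, so activity in this assay turns out to depend on more than the urea substituent. The far end of this step is a limit of the assay and not a number, and the two single changes shown from compound 1, at the urea and on the ring, both end there: the limit of > 128000 nM in this assay, at which 2 of the 3 values shown sit.

As far as these compounds go, whether chloro, methoxy or plain hydrogen at this ring position would keep a measurable value remains open. From the compounds shown here alone, the full size of the step also remains unknown, as does whether fluoro itself is needed or methyl alone is poorly tolerated.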